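The source may report more compounds than this note shows. Statements on the series, on what has been measured and on what is new or still open speak of the compounds shown alone.

Measured compounds:
- compound 1 `Cc1ccc(C)c(Nc2c(-c3ccc4[nH]nc(C)c4c3)nc3cnc(N4CCN(C)CC4)cn23)c1`: in a functional assay on MV4-11 cells (Homo sapiens) for inhibition, with a stated time of 120 h (on this read-out higher numbers stand for weaker inhibition and lower numbers for stronger inhibition), compound 1 gives "not determined" (no result reported)
- compound 2 `Cc1cc(Br)ccc1Nc1c(-c2ccc3[nH]nc(C)c3c2)nc2cnc(N3CCN(C)CC3)cn12`: in this assay compound 2 gives 10900 nM

Among the compounds with values here, compound 2 holds the only number in this assay; compound 1 carries no value, so nothing can be said of how the two compare. Compound 3 `Cc1n[nH]c2ccc(-c3nc4cnc(N5CCN(C)CC5)cn4c3Nc3ccc(Cl)cc3Cl)cc12` is the next entry. Compound 3 differs from compound 2 by 2,4-dichlorophenyl in place of 4-bromo-2-methylphenyl on a nitrogen on an aromatic ring. Within the data shown here, no step between two measured compounds is available, so the size of this change cannot be read from a comparison. In the absence of such a comparison, the expectation is for no step beyond the usual scatter, leaning weakly toward similar potency, which the estimated step of a 1.2-fold lower number from compound 2 to compound 3 (0.08 log units; within the scatter) expresses. Compound 3 is accordingly expected to come in at 9000 nM in this assay, with a range from 3000 nM to 30000 nM.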

Compound 3, half-maximal inhibitory concentration: 4720 nM
Compound 3: the middle estimate sits 1.9-fold (0.28 log units) above what was measured, and the stated range covers the measured number.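

In this assay, within the data shown here, 2,4-dichlorophenyl in place of 4-bromo-2-methylphenyl on a nitrogen on an aromatic ring gives a 2.3-fold lower number from compound 2 to compound 3 (0.36 log units; beyond the scatter), the first step that can be read. The read-out at this position therefore responds modestly to an exchange between two groups with the same heavy-atom, hydrogen-bond donor and hydrogen-bond acceptor counts, each with one six-membered aromatic ring of carbon only. No supporting data bear on why the number moves.

This single step changes the methyl and the bromine together, so the share of each remains unresolved. Also open, as far as these compounds go, is how the position responds to a group such as 4-methoxyphenyl, a pyridyl ring or a saturated cyclohexyl ring on this nitrogen.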